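The compounds below may be only part of what the source reports. "The series", "measured", "known", "first", "only" and "open" are said of these compounds alone.

Measured compounds:
compound 1 `CCOc1ncccc1-c1c(C)nn(-c2nc(-c3ccc(Cl)c(Cl)c3)c(SC(C)C)s2)c1C(=O)O`: 11000 nM
compound 2 `Cc1nn(-c2nc(-c3ccc(Cl)c(Cl)c3)c(SC(C)C)s2)c(C(=O)O)c1-c1cncc(C#N)c1`: 20000 nM

Both compounds were tested in a functional assay on BJAB cells (Homo sapiens) for antiproliferative activity, with a stated time of 4 days; on this read-out higher numbers stand for an effect only at larger amounts of compound and lower numbers for an effect already at smaller amounts. Compound 2 gives 20000 nM, the highest of the two numbers, while compound 1 gives 11000 nM. Among the compounds with values here, the single measured step, a 1.8-fold higher number from compound 1 to compound 2 (0.26 log units; within the scatter), is a change of the aryl group on the shared core and stays within the scatter.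

Compound 3 `Cc1nn(-c2nc(-c3ccc(Cl)c(Cl)c3)c(SC(C)C)s2)c(C(=O)O)c1-c1ccc(C(F)(F)F)cc1` is the next member and has not yet been measured. It differs from compound 2 in one place: 4-(trifluoromethyl)phenyl in place of 5-cyanopyridin-3-yl on an aromatic carbon.

Within the data shown here, the only step that bears on this change is the one from compound 1 to compound 2, an exchange of one aryl group for another at the same aromatic carbon, which produced no shift beyond the scatter. On that basis an exchange of the aryl group for a 4-(trifluoromethyl)phenyl is expected to give no step beyond the scatter in this assay, so the number for compound 3 is estimated as a 1.3-fold lower number from compound 2 to compound 3 (0.12 log units; within the scatter). Compound 3 is therefore expected to show about 15000 nM, in a range from 5000 nM to 45000 nM.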

Compound 3, half-maximal effective concentration: 3500 nM
The estimate for compound 3 lay 4.3-fold (0.63 log units) above the measured number; measured number below the stated range.
By their numbers in this assay, from the lowest: compound 3; then compounds 1 and 2 (each within the scatter of the next).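

In this assay, the aromatic carbon that bears the aryl group on the shared core proves sensitive to the choice of group: 4-(trifluoromethyl)phenyl gives a 5.7-fold lower number from compound 2 to compound 3 (0.76 log units; beyond the scatter) and a 3.1-fold lower number from compound 1 to compound 3 (0.50 log units; beyond the scatter), both beyond the scatter, whereas the exchange of 2-ethoxypyridin-3-yl for 5-cyanopyridin-3-yl, a 1.8-fold higher number from compound 1 to compound 2 (0.26 log units; within the scatter), stayed within it. Within the data shown here, this is the first sign that the read-out at this position can move at all, and the move is towards effect at smaller amounts of compound. The change to compound 3 replaces a ring with a hetero atom by a ring of carbon only, and it also removes the nitrile and brings in the trifluoromethyl group, and no measurement shown here explains the step.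

As far as these compounds go, the three compounds cannot separate these features, so it remains open whether the ring of carbon only or the trifluoromethyl group carries the step. An unsubstituted phenyl, a phenyl bearing a nitrile or a pyridine ring bearing a trifluoromethyl group at this aromatic carbon would each bear on that question.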